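Aryl replacements on a shared core

This account rests on a few compounds, and the source may have more. Where it says the series, first, only, none or still open, it means among the compounds named here.

Compound 1 `Cc1ccc(S(=O)(=O)Oc2ccc3c(c2C)[C@H](Cn2cc(-c4ccccc4)nn2)[C@@]24CC(=O)[C@@](C)(CC[C@@H]32)C4)cc1` carries a phenyl. In a functional assay on SMMC-7721 cells (Homo sapiens) for cytotoxicity, read by MTT assay, with a stated time of 4 days (on this read-out lower numbers stand for stronger inhibition and higher numbers for weaker inhibition), compound 1 gives only a limit of the assay, > 20000 nM. Compound 2 `Cc1ccc(S(=O)(=O)Oc2ccc3c(c2C)[C@H](Cn2cc(-c4ccccn4)nn2)[C@@]24CC(=O)[C@@](C)(CC[C@@H]32)C4)cc1` carries pyridin-2-yl in place of phenyl, and in this assay compound 2 is likewise reported only as a limit, > 20000 nM. The step that the two limits leave unreadable from compound 1 to compound 2 is unreadable, as the limit of > 20000 nM in this assay, at which 2 of the 2 values shown sit, shows. Compound 2 thus stands at the limit, with no number to set it apart from compound 1.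

Compound 3 `COc1ccc(-c2cn(C[C@H]3c4c(ccc(OS(=O)(=O)c5ccc(C)cc5)c4C)[C@@H]4CC[C@@]5(C)C[C@]43CC5=O)nn2)cc1` differs from compound 2 by 4-methoxyphenyl in place of pyridin-2-yl on an aromatic carbon. Within the data shown here, the only measured step concerns the same aromatic carbon but gives no size, since both ends sit at the limit. Nothing in the data points to a readable gain from this change. Compound 3 is therefore expected to stay at or near the limit, with an estimated 25000 nM (range 8000 nM to 80000 nM). The step that the limit leaves unreadable from compound 2 to compound 3 is expected to be none beyond the scatter.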

Compound 3, half-maximal inhibitory concentration: > 20000 nM
Compound 3: a limit, no number; the forecaster's own chance of this, stated with the estimate: 75%; the middle value is on the limit's open side.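

In this assay compound 3 gives only a limit of the assay, > 20000 nM. No step among compound 1, compound 2 and compound 3 can be read: the limit of > 20000 nM in this assay, at which 3 of the 3 values shown sit.

The compounds shown leave open whether any aryl group on the shared core gives a number in this assay.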